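A Pyrrole Ring in Place of the Chlorophenyl Group

The compounds below may be only part of what the source reports. "The series", "measured", "known", "first", "only" and "open" are said of these compounds alone.

Compound 2 `CC1=CC[C@H](C(C)(C)NC(=S)N/N=C/c2ccc(Cl)cc2)CC1` is one of two compounds on the shared core measured so far. Among the measured compounds shown here, in a functional assay on NCI/ADR-RES cells (Homo sapiens) for inhibition, read by sulforhodamine B assay, with a stated time of 48 h (on this read-out higher numbers stand for weaker inhibition of growth and lower numbers for stronger inhibition of growth), compound 2 gives 97400 nM, the only number obtained in this assay. Compound 1 `CC1=CC[C@H](C(C)(C)NC(=S)N/N=C/c2ccc(F)cc2)CC1` did not yield a number in this assay: for compound 1 the result is > 100000 nM, which is a limit of the assay (the limit of > 100000 nM in this assay, at which 1 of the 2 values shown sits). The step of an at least 1.0-fold lower number from compound 1 to compound 2 (0.01 log units; that floor lies within the scatter) accordingly stays within the scatter. Compound 3 `CC1=CC[C@H](C(C)(C)NC(=S)N/N=C/c2ccc[nH]2)CC1` remains to be measured; it differs from compound 2 in that (1H-pyrrol-2-yl in place of 4-chlorophenyl on a carbon with a double bond to nitrogen). No measured step bears directly on this change: the single step shown exchanges one halogen for another on the same ring, whereas here the whole ring is replaced. For the measured compounds named here, with both values so far at or near the limit, the expected step of a 1.0-fold higher number from compound 2 to compound 3 (0.01 log units; within the scatter) is one of no size beyond the scatter. For compound 3 the estimate in this assay is 100000 nM, with a range from 40000 nM to 250000 nM, and a real chance that again only a limit is reported.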

Compound 3, concentration for total growth inhibition: > 100000 nM
Compound 3 gave a limit, no number; the forecaster's own chance of this, stated with the estimate: 55%; the middle value lies on the limit itself.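

Exchanging 4-chlorophenyl for 1H-pyrrol-2-yl on a carbon with a double bond to nitrogen gives, in this assay, an at least 1.0-fold higher number from compound 2 to compound 3 (0.01 log units; that floor lies within the scatter), so this step shows no difference beyond the scatter, although the limit leaves its full size unknown. The earlier step changed only the halogen on the same ring, whereas this one shows that a five-membered aromatic ring with 1 hetero atom and 1 hydrogen-bond donor at this place also gives no measurable gain in growth inhibition; the step between compound 1 and compound 3 cannot be read, since both results are limits. The result for compound 3 is a limit too, which extends the pattern across the three compounds, with compound 2 the only one to give a number: the limit of > 100000 nM in this assay, at which 2 of the 3 values shown sit.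

As far as these compounds go, how far compound 1 and compound 3 lie past that limit remains open, so the true order of the three compounds cannot be told. Also open, from the compounds shown here alone, is whether a dimethylamino group or a carboxylic acid on the ring at this place would yield a value clearly away from the limit.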